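Methyl on the amide aryl: a step from compound 2

A few compounds are considered here, and "the series" means these few. Any claim that something is new, unique, unknown or untested is made for them only; others in the source may bear on it.

Compound 1, `COc1ccc2c(=O)c(/C=C/C(=O)Nc3cccc(C)c3)coc2c1`, in a functional assay on Huh-7 cells (Homo sapiens) for inhibition, read by MTT assay, with a stated time of 48 h; on this read-out higher numbers stand for weaker inhibition and lower numbers for stronger inhibition: 15500 nM
Compound 2, `COc1ccc2c(=O)c(/C=C/C(=O)Nc3ccccc3)coc2c1`, in this assay: 9050 nM
Compound 3, `COc1ccc2c(=O)c(/C=C/C(=O)NCc3ccc(F)cc3F)coc2c1`, in this assay: > 100000 nM

Compound 2 gives 9050 nM in this assay. Compound 1 gives 15500 nM, and the step of a 1.7-fold lower number from compound 1 to compound 2 (0.23 log units; within the scatter) lies within the scatter, so the two compounds cannot be told apart on these numbers. For compound 3 the value > 100000 nM is a limit of the assay and not a number; the step of an at least 11-fold higher number from compound 2 to compound 3 (1.04 log units; beyond the scatter) and the step of an at least 6.4-fold higher number from compound 1 to compound 3 (0.80 log units; beyond the scatter) rest on that limit (the limit of > 100000 nM in this assay, at which 1 of the 3 values shown sits).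

Compound 4, `COc1ccc2c(=O)c(/C=C/C(=O)Nc3ccc(C)cc3)coc2c1`, is not yet measured. It differs from compound 2 by methyl in place of hydrogen on an aromatic carbon. For the measured compounds named here, the one measured step that bears on this change is a 1.7-fold lower number from compound 1 to compound 2 (0.23 log units; within the scatter), where hydrogen replaced methyl on an aromatic carbon and the number moved within the scatter. The methyl entering compound 4 sits on a different aromatic carbon than the methyl of compound 1, so that step is a guide rather than a match. On this basis, no step beyond the scatter is expected; the step of a 1.3-fold higher number from compound 2 to compound 4 (0.12 log units; within the scatter) is the estimated outcome. Compound 4 is therefore expected to give 12000 nM, with a range from 5000 nM to 30000 nM.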

Compound 4, half-maximal inhibitory concentration: > 100000 nM
Compound 4: only a limit was reported (the forecaster's own chance of this, stated with the estimate: 5%); at least 8.3-fold (0.92 log units) between middle value and limit.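

Going from the phenyl of compound 2 to the 4-methylphenyl of compound 4 is the first single methyl change in this assay that lies beyond the scatter: an at least 11-fold higher number from compound 2 to compound 4 (1.04 log units; beyond the scatter). The place of the methyl on the aromatic ring therefore counts on these numbers, as 3-methylphenyl and 4-methylphenyl, the same group on different aromatic carbons, are separated by an at least 6.4-fold higher number from compound 1 to compound 4 (0.80 log units; beyond the scatter). Compound 4 gives > 100000 nM, which is a limit of the assay and not a number, so the true size of both steps is unknown, and the step from compound 3 to compound 4 cannot be read, as both of its values are limits: the limit of > 100000 nM in this assay, at which 2 of the 4 values shown sit.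

Going by these compounds, what stays open is whether this loss belongs to methyl alone or would also follow other groups on the same aromatic carbon, such as a methoxy, a chlorine, an amine or a carboxylic acid. The compounds shown also leave open how an unsubstituted benzyl on the amide nitrogen would read in this assay.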